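This account rests on a few compounds, and the source may have more. Where it says the series, first, only, none or still open, it means among the compounds named here.

Working notes on the series. Compound 1 `CCN(CC)S(=O)(=O)c1ccc(S(=O)(=O)N2CCC[C@@H](C(=O)N3CCN(c4nc(C(F)(F)F)no4)CC3)C2)cc1` carries a trifluoromethyl on an aromatic carbon. In a functional assay on MIA PaCa-2 cells (Homo sapiens) for inhibition, read by MTT assay, with a stated time of 3 days (a lower number here means a stronger inhibitor, a higher number a weaker inhibitor), compound 1 gives > 10000 nM, which is a limit of the assay and not a number. Compound 2 `CCN(CC)S(=O)(=O)c1ccc(S(=O)(=O)N2CCC[C@@H](C(=O)N3CCN(c4nc(C(C)C)no4)CC3)C2)cc1` differs by an isopropyl in place of the trifluoromethyl on that aromatic carbon. In this assay compound 2 gives > 10000 nM, again a limit rather than a measured number. Within the data shown here, the step that the two limits leave unreadable from compound 1 to compound 2 therefore cannot be read, and compound 2 stands nowhere definite on the numbers so far: it is known only to sit at the limit of > 10000 nM in this assay, at which 2 of the 2 values shown sit, with no numerical value anywhere to rank it against.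

Compound 3 `CCN(CC)S(=O)(=O)c1ccc(S(=O)(=O)N2CCC[C@@H](C(=O)N3CCN(C(=O)OC(C)(C)C)CC3)C2)cc1` is the next member. The change from compound 2 is tert-butoxycarbonyl in place of 3-isopropyl-1,2,4-oxadiazol-5-yl on an amine nitrogen in a ring. Among the measured compounds shown here, no measured step bears on this change; the single step in hand is unreadable because the limit of > 10000 nM in this assay, at which 2 of the 2 values shown sit, holds both of its ends. With nothing to pull the expectation either way, compound 3 is expected to remain near that same limit in this assay, estimated at 15000 nM with a range from 3000 nM to 60000 nM. The expected step that the limit leaves unreadable from compound 2 to compound 3 is thus an estimate of no change beyond the scatter.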

Compound 3, half-maximal inhibitory concentration: > 10000 nM
Compound 3: only a limit was reported; the forecaster's own chance of this, stated with the estimate: 80%; the middle value is on the limit's open side.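

Among these compounds, no step from compound 1 or compound 2 to compound 3 can be read, because both ends of each step are limits of the assay and not numbers: the limit of > 10000 nM in this assay, at which 3 of the 3 values shown sit. The compounds shown leave open how compound 1, compound 2 and compound 3 rank against one another in this assay.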